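A few compounds are considered here, and "the series" means these few. Any claim that something is new, unique, unknown or untested is made for them only; others in the source may bear on it.

Compounds 1 to 3 share one core and differ only in the group on a saturated chain carbon bound to an aromatic nitrogen. In an ADME assay on L929 cells (Mus musculus) for cytotoxicity, read by resazurin assay, with a stated time of 48 h (a lower number here means that less compound is tolerated, a higher number that more compound is tolerated), compound 1 (`C=CCn1c2ccc([N+](=O)[O-])cc2c(=O)n1Cc1ccccc1`), which carries vinyl at that place, gives 192000 nM. Compound 2 (`C#CCn1c2ccc([N+](=O)[O-])cc2c(=O)n1Cc1ccccc1`), which carries ethynyl, gives 195000 nM, and compound 3 (`COC(=O)Cn1c2ccc([N+](=O)[O-])cc2c(=O)n1Cc1ccccc1`), which carries methoxycarbonyl, gives 129000 nM. These numbers all lie within the usual scatter of one another, so compound 3 stands together with the other two rather than apart from them.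

Compound 4 (`CNC(=O)CCCn1c2ccc([N+](=O)[O-])cc2c(=O)n1Cc1ccccc1`) differs from compound 3 at that same place: 2-(methylcarbamoyl)ethyl in place of methoxycarbonyl on a saturated chain carbon bound to an aromatic nitrogen. In words, 2-(methylcarbamoyl)ethyl stands in place of methoxycarbonyl. Three measured steps at this place bear on the change: a 1.0-fold higher number from compound 1 to compound 2 (0.01 log units; within the scatter), a 1.5-fold lower number from compound 1 to compound 3 (0.17 log units; within the scatter) and a 1.5-fold lower number from compound 2 to compound 3 (0.18 log units; within the scatter). All three are within the scatter. None of them, however, brings in a group containing methylcarbamoyl, so they are only a rough guide. On this evidence, no step beyond the scatter is expected in this assay, and no direction can be favoured with confidence. The estimated step is a 1.2-fold higher number from compound 3 to compound 4 (0.09 log units; within the scatter), which is expected to stay within the scatter. For compound 4 the estimated value is 160000 nM, with an expected range from 80000 nM to 300000 nM.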

Compound 4, concentration lethal to 50% of the cells: > 256000 nM
Compound 4: no number, only a limit; the forecaster's own chance of this, stated with the estimate: 10%; middle value at least 1.6-fold (0.20 log units) from the limit.
By their numbers in this assay, from the lowest: compounds 3, 1 and 2 (each within the scatter of the next). At a limit, above all of these: compound 4.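

Compound 4 gives no number in this assay, only a limit: the limit of > 256000 nM in this assay, at which 1 of the 4 values shown sits. Set against the earlier compounds, this reads as an at least 1.9-fold higher number from compound 3 to compound 4 (0.29 log units; that floor lies within the scatter), as an at least 1.3-fold higher number from compound 2 to compound 4 (0.11 log units; that floor lies within the scatter) and as an at least 1.3-fold higher number from compound 1 to compound 4 (0.12 log units; that floor lies within the scatter), so each step has a floor and no full size, and none is shown to go beyond the scatter. Among these compounds, what is new is that this place on the saturated chain carbon bound to an aromatic nitrogen also takes 2-(methylcarbamoyl)ethyl, a group containing methylcarbamoyl, with no sign that less compound is tolerated than with vinyl, ethynyl or methoxycarbonyl.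

On these data alone, the true value of compound 4 stays unknown, so it remains open whether this change moves the number beyond the scatter at all. As far as these compounds go, it is also open whether any such shift would follow the methylcarbamoyl end or the chain that carries it, which a carboxylic acid or an amine on the same chain, or methylcarbamoyl on a shorter or longer chain, could help to separate.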